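The source may report more compounds than this note shows. Statements on the series, on what has been measured and on what is new or still open speak of the compounds shown alone.

Notes on the series in a physicochemical assay for lipophilicity; a lower number here means a more polar compound, a higher number a more lipophilic compound. Compound 1 `Cc1ccc(NC(=O)CC(CCC(=O)O)c2nnc(CCCC(C)C)n2C2CC2)c(C)c1` gives 2.9, compound 2 `Cc1ccc(NC(=O)C[C@H](CCC(=O)O)c2noc(-c3ccc(CC(C)C)cc3)c2C2CC2)c(Cl)c1` gives 4.8, and compound 3 `Cc1ccc(NC(=O)C[C@H](CCC(=O)O)c2noc(-c3cc(CC(C)C)on3)c2C2CC2)c(Cl)c1` gives 3.9. Compound 3 is thus the second highest of the three numbers, lying beyond the scatter from both others: lower than compound 2 and higher than compound 1.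

The unmeasured compound 4 `Cc1ccc(NC(=O)C[C@H](CCC(=O)O)c2noc(-c3cc(CC(C)C)no3)c2C2CC2)c(Cl)c1` has the same atoms as compound 3, joined differently: 3-isobutyl-1,2-oxazol-5-yl in place of 5-isobutyl-1,2-oxazol-3-yl on an aromatic carbon. The change lies on an aromatic carbon of a five-membered aromatic ring with 1 nitrogen and 1 oxygen, next to the ring oxygen and next to the ring atom that bears a cyclopropyl group.

Within the data shown here, one measured step bears on this: a number 0.90 log units lower from compound 2 to compound 3 (beyond the scatter). It is modest and beyond the scatter, but it replaced 4-isobutylphenyl with 5-isobutyl-1,2-oxazol-3-yl, a larger exchange than the present one. Among the measured compounds shown here, no measured pair exchanges the two isobutyl-oxazolyl groups, so the size of this step has no direct precedent. The expectation therefore stays anchored on compound 3 at 3.9, with no step beyond the scatter expected in this assay in either direction. The estimated step is a number 0.10 log units higher from compound 3 to compound 4 (within the scatter). Compound 4 is expected at 4, within an estimated range of 3.6 to 4.4.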

Compound 4, distribution coefficient: 3.8
For compound 4 the middle estimate is 0.20 log units above the measured one; the range from low to high includes it.
By their numbers in this assay, from the lowest: compound 1; then compounds 4 and 3 (each within the scatter of the next); then compound 2.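

In this assay the exchange of 5-isobutyl-1,2-oxazol-3-yl for 3-isobutyl-1,2-oxazol-5-yl on this aromatic carbon gives a number 0.10 log units lower from compound 3 to compound 4 (within the scatter) and so does not resolve the two groups, which have the same atoms joined differently and the same counts of hydrogen-bond donors and acceptors. Set against the 4-isobutylphenyl group at the same place, the second isobutyl-oxazolyl group gives a number 1.00 log units lower from compound 2 to compound 4 (beyond the scatter) as well, so compound 3 and compound 4 both lie beyond the scatter from compound 2, and the earlier step of a number 0.90 log units lower from compound 2 to compound 3 (beyond the scatter) now has a companion that does not depend on how the oxazolyl group is attached. Nothing at hand accounts for either step.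

The compounds shown leave open whether the two attachments would also stay within the scatter of each other if the isobutyl group on the 1,2-oxazolyl ring gave way to an amine or a longer chain. They also leave open where a pyridine at this place would stand relative to compound 3 and compound 2 in this assay and whether its number would fall nearer either one.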